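The source may hold more compounds than are shown below. What is called first, only, known or untested is meant among the compounds shown, and "the series" means these compounds.

Measured compounds in a functional assay on DU-145 cells (Homo sapiens) for inhibition, read by trypan blue exclusion, with a stated time of 96 h; on this read-out lower numbers stand for stronger inhibition of growth and higher numbers for weaker inhibition of growth:
compound 1 `O=C(/C(=C\c1ccc(Br)cc1)S(=O)(=O)c1ccc(Br)cc1)c1ccc(Br)cc1` gives 10000 nM.
compound 2 `COc1ccc(S(=O)(=O)/C(=C/c2ccc(Br)cc2)C(=O)c2ccc(Br)cc2)cc1` gives 6000 nM.
compound 3 `O=C(/C(=C\c1ccc(Br)cc1)S(=O)(=O)c1ccc(Br)cc1)c1ccccc1O` reaches only a limit of this assay, > 100000 nM.

Compound 1 holds the highest of the two numbers shown in this assay, with compound 2 nearest: a 1.7-fold lower number from compound 1 to compound 2 (0.22 log units; within the scatter). Compound 3 sits at the limit (the limit of > 100000 nM in this assay, at which 1 of the 3 values shown sits), so no number is known for it.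

Compound 4 `Nc1c(Br)cc(Br)cc1/C=C(\C(=O)c1ccc(Br)cc1)S(=O)(=O)c1ccc(Br)cc1` differs from compound 1 in one place:
2-amino-3,5-dibromophenyl in place of 4-bromophenyl on a double-bonded chain carbon bound to a double-bonded chain carbon

The measured steps touch other places. One is a methoxy in place of bromo on an aromatic carbon, a 1.7-fold lower number from compound 1 to compound 2 (0.22 log units; within the scatter). The other is a 2-hydroxyphenyl in place of 4-bromophenyl on a carbonyl carbon, an at least 10-fold higher number from compound 1 to compound 3 (1.00 log units; beyond the scatter). Neither alters the double-bonded chain carbon where compound 4 differs, so they give only a weak lead. The expectation for compound 4 in this assay is therefore no step beyond the scatter, estimated as no change at the digits printed from compound 1 to compound 4 (within the scatter). Compound 4 is estimated at 10000 nM, within a range from 3000 nM to 40000 nM.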

Compound 4, concentration for 50% growth inhibition: 25000 nM
Estimate against measurement, compound 4: 2.5-fold (0.40 log units) below; low and high end bracket the measured number.
By their numbers in this assay, from the lowest: compounds 2 and 1 (each within the scatter of the next); then compound 4. At a limit, above all of these: compound 3.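

Among the compounds shown here, this is the first measured change on the double-bonded chain carbon, the place that the earlier steps left untouched. In this assay, replacing 4-bromophenyl with 2-amino-3,5-dibromophenyl there gives a 2.5-fold higher number from compound 1 to compound 4 (0.40 log units; beyond the scatter), so this position responds to substitution, though only modestly for this change, and growth inhibition is weakened rather than lost to a limit of the assay. Nothing measured here accounts for the step.

The single change brings in an amine and a further bromine together, so the compounds shown cannot tell which of them carries the step. From the compounds shown here alone, it remains open how a plain 2-aminophenyl, a 4-methoxyphenyl or a phenyl bearing a carboxylic acid would behave on this same carbon.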